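A few compounds are considered here, and "the series" means these few. Any claim that something is new, unique, unknown or untested is made for them only; others in the source may bear on it.

Compound 2 `Cn1c(-c2cc(=O)c3ccccc3o2)cc(Br)c1Br` and compound 1 `O=c1cc(-c2cc(Br)c(Br)[nH]2)oc2ccccc12` share one core and differ only in hydrogen in place of methyl on an aromatic nitrogen. In a functional assay on PA-1 cells (Homo sapiens) for cytotoxicity, read by MTT assay, with stated times of 6 h and 48 h (a higher number here means a weaker inhibitor, a lower number a stronger inhibitor), compound 2 gives 600 nM. In this assay compound 1 gives 410 nM. The step of a 1.5-fold lower number from compound 2 to compound 1 (0.17 log units; within the scatter) is therefore small, and nothing in the series points to a cause for it.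

Compound 3 `Cn1c(-c2cc(-c3ccc[nH]3)no2)cc(Br)c1Br` carries a different core; the difference between the core of compound 2 and the core of compound 3 is not broken down here. In this assay compound 3 reaches only a limit of the assay, >= 100000 nM, namely (the limit of >= 100000 nM in this assay, at which 1 of the 3 values shown sits).

Compound 4 `Brc1cc(-c2cc(-c3ccc[nH]3)no2)[nH]c1Br` has not yet been measured in this assay. It differs from compound 3 by hydrogen in place of methyl on an aromatic nitrogen, the same change as from compound 2 to compound 1. Compound 4 is expected to show a number no higher from compound 3 to compound 4 (the limit leaves the size open), because the same change gave a 1.5-fold lower number from compound 2 to compound 1 (0.17 log units; within the scatter). Compound 4 is accordingly estimated at 100000 nM, between 30000 nM and 300000 nM, and the result is expected most likely to be reported again only as a limit of the assay.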

Compound 4, half-maximal inhibitory concentration: >= 100000 nM
Compound 4 was reported as a limit; the forecaster's own chance of this, stated with the estimate: 80%; the middle value sits exactly at the limit.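

In this assay compound 4 gives >= 100000 nM, a limit of the assay and not a number. For the compounds shown here, compound 3 stands at the same limit, so no step between compound 3 and compound 4 can be read: the limit of >= 100000 nM in this assay, at which 2 of the 4 values shown sit. The compounds shown leave open whether hydrogen in place of methyl on an aromatic nitrogen changes anything on this core.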